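The compounds below may be only part of what the source reports. "The series", "measured", "known", "first", "only" and "open" are said of these compounds alone.

Working notes on the pyridine amidrazone thiosemicarbazide series, measured in a functional assay on A-375 cells (Homo sapiens) for cytotoxicity, read by MTT assay, with a stated time of 72 h, tested at 10 uM; a higher number here means more inhibition of growth at the concentration tested, a lower number less inhibition of growth.

Compound 1 `N/C(=N\NC(=S)N1CCOCC1)c1ccccn1` gives 18.3%. Compound 2 `Cc1cccc(/C(N)=N/NC(=S)N2CCSCC2)n1` gives 62.6%. Compound 3 `Cc1ccnc(/C(N)=N/NC(=S)N2CCSCC2)c1` gives 74.5%, the highest of the three numbers; compound 2 is nearest, lower by a margin beyond the scatter, and compound 1 is furthest, lower by a wide margin. Compound 1 and compound 3 differ in two places, the ring attached to the thiocarbonyl and the methyl, so their gap cannot be assigned to either change on its own.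

Not yet measured is compound 4 `N/C(=N\NC(=S)N1CCSCC1)c1ccccn1`. Against compound 3 the difference is hydrogen in place of methyl on an aromatic carbon; the thiomorpholine is retained. Among the compounds with values here, no measured pair isolates this change. Going by these compounds, the two methyl-bearing thiomorpholine compounds carry the two high numbers, while compound 1, which lacks the methyl and carries the morpholine, stands far lower; how much of that gap belongs to the methyl remains open.

A downward step beyond the scatter is expected, of moderate size, as a number 29.5 percentage points lower from compound 3 to compound 4 (beyond the scatter). Compound 4 is estimated at 45%, within a range of 15% to 75%, the wide range reflecting the unresolved two-place gap.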

Compound 4, percent growth inhibition at one concentration: 83.9%
Compound 4: middle estimate off by 38.9 percentage points, on the low side; measured number outside the range, above it.
By their numbers in this assay, from the lowest: compound 1; then compound 2; then compounds 3 and 4 (each within the scatter of the next).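

In this assay, hydrogen in place of methyl on the aromatic carbon opposite the ring nitrogen gives a number 9.4 percentage points higher from compound 3 to compound 4 (within the scatter) and so leaves the two compounds indistinguishable, which means that this methyl is not required for the high number. The same exchange at the methyl site of compound 2 gives a number 21.3 percentage points higher from compound 2 to compound 4 (beyond the scatter) and this step is beyond the scatter, so in these two pairs the outcome of the exchange depends on where the methyl sits. The wide gap to compound 1 can now be assigned to a single change, since thiomorpholin-4-yl in place of morpholin-4-yl on the thiocarbonyl carbon gives a number 65.6 percentage points higher from compound 1 to compound 4 (beyond the scatter) with no methyl involved.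

No supporting data bear on why either the methyl site or the ring exchange matters here. Still open, going by these compounds, is how an amine or a carboxylic acid in place of the methyl on that aromatic carbon would read, and whether the ring exchange gives a step of similar size on a methyl-bearing compound.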